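Replacing Piperidin-1-yl with 3-Hydroxypyrrolidin-1-yl in Compound 2

The compounds below may be only part of what the source reports. "The series", "measured", "known", "first", "only" and "open" are said of these compounds alone.

Compound 2 `Cc1cc2c(c(N)nn2C)c(N2CCCCC2)n1` gives 17% in an assay on isolated protein for inhibition of MAP kinase-activated protein kinase 5 (Homo sapiens), read by mobility shift assay, tested at 30 uM; on this read-out lower numbers stand for less inhibition and higher numbers for more inhibition at the one concentration tested (going by the name of the read-out). Among the compounds with values here, the only other measured compound, compound 1 `Cc1cc2[nH]nc(N)c2c(N2CCCCC2)n1`, gives 10%, and the step of a number 7 percentage points higher from compound 1 to compound 2 (within the scatter) lies within the scatter, so the two stand level. Compound 3 `Cc1cc2c(c(N)nn2C)c(N2CC[C@H](O)C2)n1` differs from compound 2 by 3-hydroxypyrrolidin-1-yl in place of piperidin-1-yl on an aromatic carbon. Within the data shown here, no measured step touches this group, so the single measured step offers no guide to its size; with both measured numbers low, the expected step of a number 5 percentage points lower from compound 2 to compound 3 (within the scatter) is taken as small. Compound 3 is estimated at 12%, between 0% and 35%.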

Compound 3, a percentage reported as inhibition, at one concentration (the size of the read-out at that concentration, not a potency): 1%
Beside the measured number, compound 3's estimate is 11 percentage points above it; the range from low to high includes it.
By their numbers in this assay, from the lowest: compounds 3, 1 and 2 (each within the scatter of the next, the first and the last beyond it).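

In this assay, putting 3-hydroxypyrrolidin-1-yl in place of piperidin-1-yl on this aromatic carbon gives a number 16 percentage points lower from compound 2 to compound 3 (beyond the scatter), so the number responds to a change at this position, which the methyl step on the aromatic nitrogen did not show. The swap changes the ring size and adds a hydroxyl group together, so the two cannot be separated, and nothing measured here explains the drop. Open, as far as these compounds go, is how plain pyrrolidin-1-yl, morpholin-4-yl or piperazin-1-yl would read at this position, and how the opposite stereocentre would read.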